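Swapping a Methoxy for Chlorine on the Shared Core

The compounds below may be only part of what the source reports. "The series", "measured", "known", "first", "only" and "open" are said of these compounds alone.

In a functional assay on KB cells (Homo sapiens) for cytotoxicity, read by MTT assay, with a stated time of 72 h (on this read-out higher numbers stand for an effect only at larger amounts of compound and lower numbers for an effect already at smaller amounts), compound 2 `COc1ccc(/C=C2\C(=O)N(c3c(Cl)cccc3Cl)c3ccccc32)cc1` gives only a limit, > 100 ug/mL. Compound 1 `COc1ccc(/C=C2\C(=O)N(c3c(Cl)cccc3Cl)c3ccccc32)cc1OC`, which carries one more methoxy group, gives 10 ug/mL, and the step of an at least 10-fold higher number from compound 1 to compound 2 (1.00 log units; beyond the scatter) shows that taking away a methoxy weakened the effect. Compound 3 `O=C1/C(=C\c2ccc(Cl)cc2)c2ccccc2N1c1c(Cl)cccc1Cl` differs from compound 2 by chloro in place of methoxy on an aromatic carbon. Among the measured compounds shown here, no measured step tests chloro against methoxy at this position, so that single step bears on it only loosely. Compound 3 is therefore expected to stay weak, with the step of a number no higher from compound 2 to compound 3 (the limit leaves the size open) within the scatter. Compound 3 is estimated at 100 ug/mL, between 30 ug/mL and 300 ug/mL.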

Compound 3, concentration for half-maximal effect: 2 ug/mL
For compound 3 the middle estimate is 50-fold (1.70 log units) above the measured one; measured number below the stated range.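

Chloro in place of methoxy brings an at least 50-fold lower number from compound 2 to compound 3 (1.69 log units; beyond the scatter), so in this assay the group para to a large group can, in a single swap, change how much compound is needed for an effect. The earlier pair tested only the removal of a methoxy group, whereas this pair shows that replacing a methoxy group can also strengthen the effect. The size of this step rests on a limit for compound 2: the limit of > 100 ug/mL in this assay, at which 1 of the 3 values shown sits.

Only methoxy and chloro are compared at this position. From the compounds shown here alone, whether bromo, an amine or a carboxylic acid there would match chloro remains open.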